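Swapping the benzyl ring substituent toward an ethoxy group

The source may hold more compounds than are shown below. What is called first, only, known or untested is meant among the compounds shown, and "the series" means these compounds.

Measured compounds:
- compound 1 `COc1cccc(OC)c1OCCNCCOc1ccccc1OCc1ccccc1`: 26900 nM
- compound 2 `COc1cccc(OC)c1OCCNCCOc1ccccc1OCc1ccccc1C`: 11500 nM
- compound 3 `COc1cccc(OC)c1OCCNCCOc1ccccc1OCc1ccccc1[N+](=O)[O-]`: 13200 nM

These three share one core and differ only on the ring of the benzyl group attached through oxygen. In a functional assay on PC-3 cells (Homo sapiens) for cytotoxicity, read by sulforhodamine B assay (on this read-out higher numbers stand for weaker inhibition of growth and lower numbers for stronger inhibition of growth), compound 1 gives 26900 nM. Adding a methyl gave a 2.3-fold lower number from compound 1 to compound 2 (0.37 log units; beyond the scatter), and adding a nitro gave a 2.0-fold lower number from compound 1 to compound 3 (0.31 log units; beyond the scatter); between the two substituted compounds there was a 1.1-fold higher number from compound 2 to compound 3 (0.06 log units; within the scatter). Compound 3 therefore sits close to compound 2 and beyond the scatter from compound 1.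

Compound 4 `CCOc1ccc(COc2ccccc2OCCNCCOc2c(OC)cccc2OC)cc1` has not yet been measured. Its difference from compound 3 is 4-ethoxyphenyl in place of 2-nitrophenyl on a saturated chain carbon bound to an oxygen on an aromatic ring. Within the data shown here, none of the measured steps covers this exact exchange: the nitro and methyl steps show that substituting this ring lowers the number modestly, but they say nothing about a 4-ethoxyphenyl group, and the difference between nitro and methyl was within the scatter. The step of a 1.1-fold lower number from compound 3 to compound 4 (0.04 log units; within the scatter) is therefore expected to stay within the scatter, with the number remaining close to that of compound 3. The estimate for compound 4 in this assay is 12000 nM, expected to fall between 5000 nM and 30000 nM.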

Compound 4, concentration for 50% growth inhibition: 5200 nM
The estimate for compound 4 lay 2.3-fold (0.36 log units) above the measured number; measured number inside the range.
By their numbers in this assay, from the lowest: compound 4; then compounds 2 and 3 (each within the scatter of the next); then compound 1.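

In this assay, the 4-ethoxyphenyl group separates itself from both earlier substituted rings, with a 2.5-fold lower number from compound 3 to compound 4 (0.40 log units; beyond the scatter) and a 2.2-fold lower number from compound 2 to compound 4 (0.34 log units; beyond the scatter), although compound 2 and compound 3 lie within the scatter of each other. So at this position the choice of substituent matters, not only whether the ring carries one, and the step from the unsubstituted ring, a 5.2-fold lower number from compound 1 to compound 4 (0.71 log units; beyond the scatter), is a clearer change than either methyl or nitro gave. Nothing available here gives a reason for this lower number.

The names 2-nitrophenyl and 4-ethoxyphenyl differ both in the group and in its numbered place on the ring, so the compounds shown cannot say which of the two drives the step. They also leave open whether a longer chain such as propoxy, or an amine, would carry the trend further.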